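Swapping an Aryl Amide for an Aryl Urea

The source may report more compounds than this note shows. Statements on the series, on what has been measured and on what is new or still open speak of the compounds shown alone.

Compound 1 `Cc1ccccc1C(=O)NC1CCN(c2ncnc3[nH]ncc23)CC1` in an assay on isolated protein for inhibition of serine/threonine-protein kinase PAK 1 (Homo sapiens), read by ADP-Glo, with a stated time of 40 min; a lower number here means a stronger inhibitor, a higher number a weaker inhibitor: 6260 nM
Compound 2 `O=C(NC1CCN(c2ncnc3[nH]ncc23)CC1)c1cccc(Cl)c1Cl` in this assay: 4170 nM

Among these two numbers compound 2 stands lowest, with compound 1 nearest; the only measured step, a 1.5-fold lower number from compound 1 to compound 2 (0.18 log units; within the scatter), came from a 2,3-dichlorophenyl in place of 2-methylphenyl on the carbonyl carbon, and it stayed within the scatter.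

Compound 3 `Cc1cccc(C)c1NC(=O)NC1CCN(c2ncnc3[nH]ncc23)CC1` differs from compound 2 by (2,6-dimethylphenyl)amino in place of 2,3-dichlorophenyl on a carbonyl carbon. Within the data shown here, no measured step bears on exchanging the aryl group on the carbonyl carbon for an arylamino group; the single step known, which altered only the aryl group, was within the scatter. With nothing in the data pointing either way, the step from compound 2 is expected to stay within the scatter, a 1.2-fold higher number from compound 2 to compound 3 (0.08 log units; within the scatter), though the range is kept wide for lack of a comparable step. Compound 3 is therefore estimated at 5000 nM, with a range from 1500 nM to 20000 nM.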

Compound 3, half-maximal inhibitory concentration: 2160 nM
For compound 3 the middle estimate is 2.3-fold (0.36 log units) above the measured one; low and high end bracket the measured number.
By their numbers in this assay, from the lowest: compounds 3, 2 and 1 (each within the scatter of the next, the first and the last beyond it).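

In this assay, putting (2,6-dimethylphenyl)amino on the carbonyl carbon gave a 1.9-fold lower number from compound 2 to compound 3 (0.29 log units; within the scatter) where it replaced 2,3-dichlorophenyl, and a 2.9-fold lower number from compound 1 to compound 3 (0.46 log units; beyond the scatter) where it replaced 2-methylphenyl. Among these compounds, this position therefore accepts an arylamino group, which brings one hydrogen-bond donor, in place of an aryl group, and the change to this group yields the first step here to clear the scatter, though only against one of the two aryl amides. Nothing available explains this result.

The compounds shown leave open whether the step belongs to the amino nitrogen or to the two methyl groups on the ring, as the aryl group and the linking atom change together in both steps. A plain 2,6-dimethylphenyl or a (2,3-dichlorophenyl)amino on the carbonyl carbon would separate the two, and a benzylamino group would test a longer link.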